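This account rests on a few compounds, and the source may have more. Where it says the series, first, only, none or still open, it means among the compounds named here.

In a functional assay on KG-1 cells (Homo sapiens) for cytotoxicity, read by luminescence and CellTiter-Glo, with a stated time of 3 days (on this read-out higher numbers stand for weaker inhibition and lower numbers for stronger inhibition), two compounds give numbers and one does not. Compound 1 `N#Cc1ccc(NC(=O)c2ccc(Br)cc2O)cc1Cl` gives 960 nM. Compound 3 `N#Cc1ccc(NC(=O)c2ccc(C(F)(F)F)cc2O)cc1` gives 1440 nM; of the two numbers shown this is the higher, yet the gap to compound 1 lies within the scatter, so the two cannot be told apart. Compound 2 `N#Cc1ccc(NC(=O)c2ccc[nH]c2=O)cc1` shows only a limit of the assay, > 10000 nM. Compound 4 `N#Cc1ccc(NC(=O)c2ccccc2O)cc1` has not been measured. It differs from compound 3 in one place: hydrogen in place of trifluoromethyl on an aromatic carbon. Among the measured compounds shown here, no measured pair shows this change. Removing the trifluoromethyl is expected to weaken inhibition by a moderate step, a 2.8-fold higher number from compound 3 to compound 4 (0.44 log units; beyond the scatter). Compound 4 is therefore estimated at 4000 nM, likely between 1200 nM and 12000 nM.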

Compound 4, half-maximal inhibitory concentration: 5370 nM
Compound 4: the middle estimate sits 1.3-fold (0.13 log units) below what was measured; low and high end bracket the measured number.
By their numbers in this assay, from the lowest: compounds 1 and 3 (each within the scatter of the next); then compound 4. At a limit, above all of these: compound 2.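

Trifluoromethyl at this position, meta to a hydroxy group, counts for something in this assay: with hydrogen there, inhibition is clearly weaker (a 3.7-fold higher number from compound 3 to compound 4 (0.57 log units; beyond the scatter)). Even so, compound 4 still gives a measured number rather than a limit, so some inhibition remains without the group. Nothing measured here bears on why the step has this size. As far as these compounds go, it remains open whether a methyl group or an amine in the same place would match trifluoromethyl or fall to the level of hydrogen. A single pair also cannot show whether this step would hold on a different core.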